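Fluoro for hydrogen on the aromatic ring: compound 3

The source may hold more compounds than are shown below. What is called first, only, known or untested is meant among the compounds shown, and "the series" means these compounds.

Compound 1 `NC1=N[C@@H](c2ccccc2Cl)CO1` and compound 2 `NC1=N[C@@H](c2ccccc2)CO1` share a core and differ only at the aromatic carbon that carries chloro in compound 1. In a functional assay on HEK293 cells for agonist activity at trace amine-associated receptor 1 (Homo sapiens), read by cAMP accumulation, with a stated time of 30 min (a lower number here means that less compound is needed, a higher number that more compound is needed for the effect), compound 1 gives 23 nM, and compound 2 gives 67 nM. Among the measured compounds shown here, compound 2 thus stands highest of the two numbers measured so far; its only neighbour is compound 1, and the step of a 2.9-fold higher number from compound 1 to compound 2 (0.46 log units; beyond the scatter) is modest yet beyond the scatter.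

Compound 3 `NC1=N[C@@H](c2cccc(F)c2)CO1` is next to be measured. Relative to compound 2 the change is fluoro in place of hydrogen on an aromatic carbon. For the measured compounds named here, the single measured step that bears on it is the removal of a halogen from an aromatic carbon, a 2.9-fold higher number from compound 1 to compound 2 (0.46 log units; beyond the scatter), which raised the number modestly. Going by the values given here, compound 3 brings a halogen back, but a different one, placed meta to a group of 6 heavy atoms rather than where the chloro of compound 1 sat, so no measured pair maps onto it directly. A step toward a lower number, small at most, is expected, a 1.3-fold lower number from compound 2 to compound 3 (0.13 log units; within the scatter). Compound 3 is therefore estimated at 50 nM in this assay, with a range from 20 nM to 130 nM.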

Compound 3, half-maximal effective concentration: 490 nM
The estimate for compound 3 lay 9.8-fold (0.99 log units) below the measured number; the measured number lies above the stated range.
By their numbers in this assay, from the lowest: compound 1; then compound 2; then compound 3.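

Adding a fluoro meta to a group of 6 heavy atoms raises the number in this assay rather than lowering it, with a 7.3-fold higher number from compound 2 to compound 3 (0.86 log units; beyond the scatter) as the step, so a halogen on this aromatic ring does not lower the number wherever it sits. Compound 2, the unsubstituted phenyl case, now lies between its two halogenated neighbours: removing the chloro gave a 2.9-fold higher number from compound 1 to compound 2 (0.46 log units; beyond the scatter) in the same upward direction, so compound 1 fits a lowering by halogen and compound 3 goes against it. No measurement shown explains why this fluoro raises the number.

Whether the rise follows the fluoro itself or this place on the ring remains open, as compound 2 has only two substituted neighbours, and these differ from it in both the halogen and its place, with neither a fluoro where compound 1 carries chloro nor a chloro meta to a group of 6 heavy atoms among the compounds shown. Also open, from the compounds shown here alone, is how a methyl, a methoxy or a nitrile on this same aromatic carbon would read in this assay relative to compound 2 and compound 3.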